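A few compounds are considered here, and "the series" means these few. Any claim that something is new, unique, unknown or untested is made for them only; others in the source may bear on it.

Compound 1 `CN(C)/C(=N/CCCCn1nc(-c2ccccc2)ccc1=O)NC#N`: 30.3 mg/kg
Compound 2 `C/N=C(/NC#N)NCCCCn1nc(-c2ccc(C)cc2)ccc1=O`: > 100 mg/kg
Compound 3 `CCC/N=C(/NC#N)NCCCn1nc(-c2ccccc2)ccc1=O`: 100 mg/kg

All three were tested in a functional assay on the whole organism (stomach) with Rattus norvegicus as the target; on this read-out higher numbers stand for an effect only at larger amounts of compound and lower numbers for an effect already at smaller amounts. In this assay compound 1 gives 30.3 mg/kg, the lowest of the two plain numbers. Compound 3 gives 100 mg/kg, and its gap to compound 1 lies clearly beyond the usual scatter of such measurements. For compound 2 the result is only a limit of the assay, > 100 mg/kg, so no number is known for it. Going by the values given here, each pair of measured compounds differs in more than one place, so no single step between them can be read directly.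

Compound 4 `C=CCNC(=S)NCCCCn1nc(-c2ccccc2)ccc1=O` has not yet been measured. It differs from compound 1 in one place: a group of 7 heavy atoms (4 carbon, 2 nitrogen, 1 sulfur; no ring) in place of a group of 8 heavy atoms (4 carbon, 4 nitrogen; no ring), on a saturated chain carbon, four bonds along the chain from an aromatic nitrogen. Among the compounds with values here, no measured pair shares this change, so its size can only be estimated. Because compound 3 gives 100 mg/kg while compound 1 gives 30.3 mg/kg, compound 4 is expected to sit at a somewhat higher number than compound 1, with the expected step being a 2.0-fold higher number from compound 1 to compound 4 (0.30 log units; within the scatter). The estimate for compound 4 in this assay is 60 mg/kg, expected to fall between 20 mg/kg and 200 mg/kg.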

Compound 4, dose for half-maximal effect: > 100 mg/kg
Compound 4: a limit, no number (the forecaster's own chance of this, stated with the estimate: 30%); at least 1.6-fold (0.22 log units) between middle value and limit.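

In this assay compound 4 gives > 100 mg/kg, which is a limit of the assay and not a number. Going by these compounds alone, this is the first comparison in the set where only one place differs: on a saturated chain carbon, four bonds along the chain from an aromatic nitrogen, a group of 7 heavy atoms (4 carbon, 2 nitrogen, 1 sulfur; no ring) replaces a group of 8 heavy atoms (4 carbon, 4 nitrogen; no ring), and the result is an at least 3.3-fold higher number from compound 1 to compound 4 (0.51 log units; beyond the scatter). So the group at the end of this chain does matter for the dose needed in the rat stomach read-out, with the group in compound 1 the better of the two, but the step has only a lower bound and its true size remains unknown: the limit of > 100 mg/kg in this assay, at which 2 of the 4 values shown sit.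

The group in compound 4 differs from that in compound 1 in several atoms at once, so the compounds shown cannot tell which part of the swap accounts for the step. Going by these compounds, it also remains open how a simple urea, an amine or a carboxylic acid at this place would compare with compound 1.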